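The source may report more compounds than this note shows. Statements on the series, on what has been measured and on what is new or still open speak of the compounds shown alone.

Measured so far in an assay on CHO cells for antagonist activity at transient receptor potential cation channel subfamily V member 1 (Homo sapiens), read by FLIPR; a lower number here means a stronger inhibitor, a higher number a weaker inhibitor:

- compound 1 `CC(C(=O)NCc1ccc(C(F)(F)F)cc1N1CCC(C(F)(F)F)CC1)c1ccc(NS(C)(=O)=O)c(F)c1`: compound 1 gives 0.4 nM
- compound 2 `CC(C(=O)NCc1ccc(C(F)(F)F)cc1N1CCN(C2CCCCC2)CC1)c1ccc(NS(C)(=O)=O)c(F)c1`: compound 2 gives 13.8 nM
- compound 3 `CC(C(=O)NCc1ccc(C(F)(F)F)cc1N1CCN(c2ccccc2)CC1)c1ccc(NS(C)(=O)=O)c(F)c1`: compound 3 gives 2 nM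

Compound 3 holds the second highest of these three numbers. Its nearest neighbour is compound 1, with a 5.0-fold higher number from compound 1 to compound 3 (0.70 log units; beyond the scatter); its furthest is compound 2, with a 6.9-fold lower number from compound 2 to compound 3 (0.84 log units; beyond the scatter).

Compound 4 `CCCOc1cc(C(F)(F)F)ccc1CNC(=O)C(C)c1ccc(NS(C)(=O)=O)c(F)c1` is not yet measured. The change from compound 3 is: propoxy in place of 4-phenylpiperazin-1-yl on an aromatic carbon. Every measured step in the series concerns this same aromatic carbon, so all three bear on it: a 35-fold higher number from compound 1 to compound 2 (1.54 log units; beyond the scatter), a 5.0-fold higher number from compound 1 to compound 3 (0.70 log units; beyond the scatter), and a 6.9-fold lower number from compound 2 to compound 3 (0.84 log units; beyond the scatter). Each change made there so far has moved the number beyond the scatter, and the smaller of the measured differences still counted as modest. The entering propoxy is a short chain with no ring, unlike any group measured at this position, so a rise in this assay beyond the scatter is expected, though its size is uncertain. Compound 4 is therefore estimated at 30 nM, with a range from 5 nM to 200 nM. The expected step is a 15-fold higher number from compound 3 to compound 4 (1.18 log units; beyond the scatter).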

Compound 4, inhibition constant: 2 nM
Beside the measured number, compound 4's estimate is 15-fold (1.18 log units) above it, outside the stated range (below it).
By their numbers in this assay, from the lowest: compound 1; then compounds 3 and 4 (each within the scatter of the next); then compound 2.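

In this assay, a ring is not required at this aromatic carbon for a low number: with propoxy in place of 4-phenylpiperazin-1-yl, the group drops from 12 heavy atoms to 4, yet the result is no change at the digits printed from compound 3 to compound 4 (within the scatter). Against the other two groups, the same chain gives a 6.9-fold lower number from compound 2 to compound 4 (0.84 log units; beyond the scatter) but also a 5.0-fold higher number from compound 1 to compound 4 (0.70 log units; beyond the scatter), so among these four compounds, compound 1 keeps the lowest number, and group size alone does not order the series. Nothing available here accounts for this result.

As far as these compounds go, it remains open how a shorter ethoxy chain, a longer butoxy chain or a branched isopropoxy group would read at this carbon. Also open, from the compounds shown here alone, is whether a terminal trifluoromethyl group on the propoxy chain would bring the number closer to that of compound 1.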